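A few compounds are considered here, and "the series" means these few. Any claim that something is new, unique, unknown or untested is made for them only; others in the source may bear on it.

Working notes on the series. Compound 1 `Oc1cccc(-c2cc(-c3cccnc3)nc(-c3cccc(Cl)c3)c2)c1` and compound 2 `Oc1ccc(-c2cc(-c3ccccn3)nc(-c3ccccc3Cl)c2)cc1` have been tested in an assay on isolated protein for inhibition of DNA topoisomerase 1 (Homo sapiens), with a stated time of 30 min, tested at 100 uM; a lower number here means a weaker effect, a higher number a stronger effect of the compound at the concentration tested. In this assay compound 1 gives 27.6%, and compound 2 gives 5.2%. Compound 2 therefore stands lowest of the two numbers shown so far, with compound 1 the nearest and well above it, a gap beyond the usual scatter. Going by the values given here, only two compounds are measured, and they differ from each other in more than one place, so no single-change step between measured compounds is available to guide what follows.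

Compound 3 `Oc1ccc(-c2cc(-c3ccccc3)nc(-c3ccccc3Cl)c2)cc1` is the next to be measured in this assay. It departs from compound 2 in one place: phenyl in place of pyridin-2-yl on an aromatic carbon. The change sits on an aromatic carbon next to the ring nitrogen of the shared core and removes the one hydrogen-bond acceptor of the leaving group.

Among the compounds with values here, with no measured step of this kind to lean on, the expected change from compound 2 to compound 3 is a number 3.8 percentage points higher from compound 2 to compound 3 (within the scatter), a step not clearly beyond the scatter in either direction. Compound 3 is thus estimated at 9% in this assay, with a range from 0% to 28%.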

Compound 3, a percentage reported as inhibition, at one concentration (the size of the read-out at that concentration, not a potency): 13.6%
Beside the measured number, compound 3's estimate is 4.6 percentage points below it; the range from low to high includes it.
By their numbers in this assay, from the lowest: compounds 2 and 3 (each within the scatter of the next); then compound 1.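

In this assay, going by these compounds alone, phenyl in place of pyridin-2-yl on an aromatic carbon gives a number 8.4 percentage points higher from compound 2 to compound 3 (within the scatter), the first single-change step. At this position next to the ring nitrogen of the shared core, exchanging one six-membered aromatic ring for the other, and with it losing the hydrogen-bond acceptor of pyridin-2-yl, therefore does not separate compound 2 from compound 3 at the concentration tested, so this step gives no sign that the acceptor matters here. No measurement is available that would explain this outcome.

The compounds shown leave open whether a group of a different kind at this position, such as an aliphatic amine, a carboxylic acid or a saturated piperidine ring, would move the read-out beyond the scatter. Within the data shown here, also open is what the 2-chlorophenyl and 4-hydroxyphenyl groups contribute, as no step so far changes either of them alone.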